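Amino group swap on the propyl chain: benzylamino next

The compounds below may be only part of what the source reports. "The series", "measured", "known", "first", "only" and "open" are said of these compounds alone.

Measured in a functional assay on MCF7 cells (Homo sapiens) for antiproliferative activity; on this read-out lower numbers stand for stronger inhibition and higher numbers for weaker inhibition:
- compound 1 `CCN(CC)CCCOc1ccc2cc(NC(=O)c3ccc(O)c(CC=C(C)C)c3)c(=O)oc2c1C`: 6390 nM
- compound 2 `CC(C)=CCc1cc(C(=O)Nc2cc3ccc(OCCCN(C)C4CCCCC4)c(C)c3oc2=O)ccc1O`: 1080 nM

Of the two measured compounds, compound 2 has the lower number, at 1080 nM. Next is compound 3 `CC(C)=CCc1cc(C(=O)Nc2cc3ccc(OCCCNCc4ccccc4)c(C)c3oc2=O)ccc1O`, not yet measured, with benzylamino in place of cyclohexyl(methyl)amino on a saturated chain carbon, three bonds along the chain from an oxygen on an aromatic ring.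

Going by the values given here, only one measured step bears on this: a 5.9-fold lower number from compound 1 to compound 2 (0.77 log units; beyond the scatter). It shows that a change of amino group at this place can move the number, but it does not involve benzylamino, so the direction remains poorly fixed. A small step towards a higher number is expected in this assay, perhaps none beyond the scatter and smaller than that measured step. The expected step is a 1.8-fold higher number from compound 2 to compound 3 (0.25 log units; within the scatter). The estimate for compound 3 is 1900 nM, with an expected range of 650 nM to 5500 nM.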

Compound 3, half-maximal inhibitory concentration: 910 nM
Estimate against measurement, compound 3: 2.1-fold (0.32 log units) above, within the range that was stated.
By their numbers in this assay, from the lowest: compounds 3 and 2 (each within the scatter of the next); then compound 1.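

In this assay, benzylamino in place of cyclohexyl(methyl)amino gives a 1.2-fold lower number from compound 2 to compound 3 (0.07 log units; within the scatter), so at this place the read-out does not separate an aromatic from a non-aromatic six-membered carbon ring, nor a group with a hydrogen-bond donor from one without. Benzylamino in place of diethylamino gives a 7.0-fold lower number from compound 1 to compound 3 (0.85 log units; beyond the scatter), so the step away from diethylamino is not confined to cyclohexyl(methyl)amino: both ring-bearing amino groups shown share it, and no compound shown goes against this. Nothing available gives a reason for these steps.

Benzyl(methyl)amino and cyclohexylamino would separate the role of the amine hydrogen from that of the ring type, which these compounds confound. Open too, going by these compounds, is how a morpholine on the same propyl chain, or benzylamino on a longer chain, would read.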